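The source may hold more compounds than are shown below. What is called first, only, known or untested is meant among the compounds shown, and "the series" means these compounds.

For the measured compounds named here, compound 2 `O=C(O)CC/C=C\CC1COC(c2cccnc2)OC1c1cccnc1` is one of two compounds measured in an assay for inhibition of Thromboxane-A synthase (Homo sapiens), using microsomes; a higher number here means a weaker inhibitor, a lower number a stronger inhibitor; compound 2 gives 220 nM, while compound 1 `O=C(O)CC/C=C\CC1COC(c2ccc(Cl)cc2Cl)OC1c1cccnc1` gives 42 nM, so compound 2 stands as the higher of the two numbers. Going by the values given here, the single step measured, a 5.2-fold higher number from compound 1 to compound 2 (0.72 log units; beyond the scatter), is pyridin-3-yl replacing 2,4-dichlorophenyl on a saturated ring carbon. Compound 3 `O=C(O)CC/C=C\CC1COC(c2ccsc2)OC1c1cccnc1` carries thiophen-3-yl in place of pyridin-3-yl on a saturated ring carbon. Among the compounds with values here, no measured step covers this exact change, but because compound 1 gives 42 nM with a non-pyridyl group at the same place, a move away from pyridin-3-yl looks favourable. The expected step is therefore a 2.4-fold lower number from compound 2 to compound 3 (0.39 log units; beyond the scatter). Compound 3 is estimated at 90 nM, within 35 nM to 250 nM.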

Compound 3, half-maximal inhibitory concentration: 500 nM
Estimate against measurement, compound 3: 5.6-fold (0.74 log units) below; the measured number lies above the stated range.
By their numbers in this assay, from the lowest: compound 1; then compound 2; then compound 3.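

At the saturated ring carbon between two ring oxygen atoms, thiophen-3-yl replacing pyridin-3-yl in this assay gives a 2.3-fold higher number from compound 2 to compound 3 (0.36 log units; beyond the scatter) and so does not improve inhibition. Replacing 2,4-dichlorophenyl with thiophen-3-yl gives a 12-fold higher number from compound 1 to compound 3 (1.08 log units; beyond the scatter), showing that the low number of compound 1 does not extend to every group other than pyridin-3-yl. No supporting evidence explains this order. Still open, as far as these compounds go, is whether a plain phenyl or a 4-chlorophenyl group at this carbon would give a number close to that of compound 1.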